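A few compounds are considered here, and "the series" means these few. Any claim that something is new, unique, unknown or untested is made for them only; others in the source may bear on it.

Measured compounds:
- compound 1 `COc1cc2c(Oc3ccc(NC(=O)c4nccc(-c5ccc(F)cc5)n4)cc3F)ccnc2cc1OCCCN1CCCCC1`: 120 nM
- compound 2 `COc1cc2c(Oc3ccc(NC(=O)c4nccc(-c5ccccc5)n4)cc3F)ccnc2cc1OCCCN1CCCC1`: 390 nM
- compound 3 `COc1cc2c(Oc3ccc(NC(=O)c4nccc(-c5ccc(C)cc5)n4)cc3F)ccnc2cc1OCCCN1CCCC1`: 670 nM

These three share one core and differ in two places: the group on the outer six-membered carbon ring and the ring at the end of the side chain. Within the data shown here, in a functional assay on HT-29 cells (Homo sapiens) for cytotoxicity, read by MTT assay, with a stated time of 72 h (a higher number here means a weaker inhibitor, a lower number a stronger inhibitor), compound 3 gives 670 nM, the highest number of the three, and its closest neighbour is compound 2 with 390 nM; the only single-place step among them, a 1.7-fold higher number from compound 2 to compound 3 (0.24 log units; within the scatter), stays within the scatter. Compound 1, which gives 120 nM, differs from compound 3 in two places at once, so its gap cannot be attributed to one change.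

Compound 4 `COc1cc2c(Oc3ccc(NC(=O)c4nccc(-c5ccc(F)cc5)n4)cc3F)ccnc2cc1OCCCN1CCCC1` is compound 3 with one change: fluoro in place of methyl on an aromatic carbon. Among the measured compounds shown here, no measured step tests fluoro against methyl directly. What can be said is that the step from compound 2 to compound 3 was small, and that compound 1, the only fluoro-bearing compound, gives the lowest number shown, though with a different chain-end ring. On that basis a modest move to a lower number, a 2.7-fold lower number from compound 3 to compound 4 (0.43 log units; beyond the scatter), is expected, but it may well stay within the scatter. Compound 4 is estimated at 250 nM, in a range from 100 nM to 600 nM.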

Compound 4, half-maximal inhibitory concentration: 160 nM
Estimate against measurement, compound 4: 1.6-fold (0.19 log units) above, and the stated range covers the measured number.
By their numbers in this assay, from the lowest: compounds 1 and 4 (each within the scatter of the next); then compounds 2 and 3 (each within the scatter of the next).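

In this assay, fluoro in place of methyl on the aromatic carbon para to a large group gives a 4.2-fold lower number from compound 3 to compound 4 (0.62 log units; beyond the scatter) and so shows that the choice of group here can move the number beyond the scatter, something the earlier step of a 1.7-fold higher number from compound 2 to compound 3 (0.24 log units; within the scatter) did not show. Fluoro in place of hydrogen gives a 2.4-fold lower number from compound 2 to compound 4 (0.39 log units; beyond the scatter) as well, so among these three compounds with the pyrrolidin-1-yl chain end, fluoro stands apart from both hydrogen and methyl, while those two remain within the scatter of each other. Pyrrolidin-1-yl in place of piperidin-1-yl gives a 1.3-fold higher number from compound 1 to compound 4 (0.12 log units; within the scatter) and stays within the scatter, so this pair of fluoro compounds shows no readable difference between the two chain-end rings.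

From the compounds shown here alone, whether the 4-fluorophenyl result extends to other groups at this position, such as chloro, methoxy or a nitrile, remains open, as does its behaviour with a morpholine at the chain end. Nothing given here offers a measured explanation for the difference between fluoro and the other two groups.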